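Trifluoromethyl for methyl at the assay limit

The source may hold more compounds than are shown below. What is called first, only, known or untested is meant among the compounds shown, and "the series" means these compounds.

In a functional assay on HCT-116 cells (Homo sapiens) for inhibition (on this read-out higher numbers stand for weaker inhibition and lower numbers for stronger inhibition), compound 1 `CC(=O)Oc1ccc(/C=C/c2ccc3ccccc3c2)cc1` gives > 5000 nM as a limit. Compound 2 `FC(F)(F)Oc1ccc(/C=C/c2ccc3ccccc3c2)cc1` gives > 5000 nM as a limit too. Compound 3 `Cc1ccc(/C=C/c2ccc3ccccc3c2)cc1` gives > 5000 nM as a limit as well, so it has no exact standing in the series. Compound 4 `FC(F)(F)c1ccc(/C=C/c2ccc3ccccc3c2)cc1` has trifluoromethyl in place of methyl on an aromatic carbon and is unmeasured. The nearest measured changes are a step that the two limits leave unreadable from compound 2 to compound 3 and a step that the two limits leave unreadable from compound 1 to compound 3 and give no size to carry over. Going by the values given here, the only guide is the limit of > 5000 nM in this assay, at which 3 of the 3 values shown sit, and it offers no direction, so no change beyond the scatter is expected in this assay here. The estimated change is a step that the limit leaves unreadable from compound 3 to compound 4 and no more. For compound 4 the expected value is 8000 nM with an estimated range from 3000 nM to 30000 nM in this assay.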

Compound 4, half-maximal inhibitory concentration: > 5000 nM
Compound 4 gave a limit, no number; the forecaster's own chance of this, stated with the estimate: 80%; the middle value does not contradict the limit.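

In this assay compound 4, like compound 1, compound 2 and compound 3, gives only a limit, so no step among these compounds can be read: the limit of > 5000 nM in this assay, at which 4 of the 4 values shown sit.

The compounds shown leave open whether any group at this place on the shared core gives a readable value.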